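The source may report more compounds than this note shows. Statements on the series, on what has been measured and on what is new or still open speak of the compounds shown alone.

Measured so far, in a functional assay on Huh-7 cells (Homo sapiens) for cytotoxicity, with a stated time of 48 h; on this read-out higher numbers stand for weaker inhibition and lower numbers for stronger inhibition:
Compound 1 `O=[N+]([O-])c1ccc(CN2CCC(n3cc(CC(OCc4cc(-c5ccccc5)no4)c4ccc(Br)cc4)nn3)CC2)cc1` gives 7000 nM.
Compound 2 `O=[N+]([O-])c1ccc(CN2CCC(n3cc(CC(OCc4cc(-c5ccc(Br)cc5)no4)c4ccc(Br)cc4)nn3)CC2)cc1` gives 2000 nM.

For the measured compounds named here, compound 2 holds the lower of the two numbers in this assay; its only neighbour is compound 1, which sits a clear distance above it, since the step from compound 1 to compound 2 reads a 3.5-fold lower number from compound 1 to compound 2 (0.54 log units; beyond the scatter).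

Compound 3 `O=[N+]([O-])c1ccc(CN2CCC(n3cc(CC(OCc4cc(-c5ccc(F)cc5)no4)c4ccc(Br)cc4)nn3)CC2)cc1` is compound 2 with a single alteration: fluoro in place of bromo on an aromatic carbon. Going by the values given here, the one measured step that touches the same place is the one from compound 1 to compound 2, where bromo entered in place of hydrogen and the number came down by a modest but real amount. Compound 3 keeps a halogen at that spot, yet not the same one as compound 2, so the full benefit seen in that step is not assumed to carry over.

On that basis the number for compound 3 in this assay is expected to lie between those of compound 1 and compound 2, estimated at 4000 nM with a range of 1800 nM to 9000 nM, which corresponds to an expected step of a 2.0-fold higher number from compound 2 to compound 3 (0.30 log units; within the scatter).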

Compound 3, half-maximal inhibitory concentration: 2000 nM
Compound 3: middle estimate off by 2.0-fold (0.30 log units), on the high side; the measured number falls inside the stated range.
By their numbers in this assay, from the lowest: compounds 2 and 3 (each within the scatter of the next); then compound 1.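

In this assay, exchanging bromo for fluoro on the aromatic ring gives no change at the digits printed from compound 2 to compound 3 (within the scatter), while placing fluoro where compound 1 carries hydrogen gives a 3.5-fold lower number from compound 1 to compound 3 (0.54 log units; beyond the scatter), a step of the same size as a 3.5-fold lower number from compound 1 to compound 2 (0.54 log units; beyond the scatter). For the compounds shown here, this adds something that the first pair of compounds could not show: the lower number seen with bromo is not specific to bromo, as fluoro at the same place gives a matching result, so in this small set the two halogens cannot be told apart at this position. Nothing available explains why these two halogens read alike or why either differs from hydrogen.

The compounds shown leave open whether a halogen is needed here at all, and a methyl, a methoxy or a nitrile at the same place would help separate a halogen-specific result from one shared by other groups in place of hydrogen. They also leave open whether chloro would fall in line with bromo and fluoro, and whether the same step would appear in a compound with a different group in place of the nitro group.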